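From Furan Amide to Carboxy in Compound 4

The source may report more compounds than this note shows. Statements on the series, on what has been measured and on what is new or still open speak of the compounds shown alone.

In an ADME assay on J774.1 cells (Mus musculus) for cytotoxicity, read by resazurin assay, with a stated time of 48 h (a higher number here means a weaker inhibitor, a lower number a stronger inhibitor), compound 2 `CCCn1cc(C(=O)NCc2ccco2)c(=O)c2cc(F)c(N3CCC(C(N)=O)CC3)cc21` gives 56900 nM. Compound 1 `CCCn1cc(C(=O)NCc2ccc(OC)cc2)c(=O)c2cc(F)c(N3CCC(C(N)=O)CC3)cc21` gives 41400 nM and compound 3 `CCCCn1cc(C(=O)NCc2ccco2)c(=O)c2cc(F)c(N3CCC(C(N)=O)CC3)cc21` gives 41400 nM, which leaves compound 2 within the scatter of both.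

Compound 4 `CCCn1cc(C(=O)O)c(=O)c2cc(F)c(N3CCC(C(N)=O)CC3)cc21` differs from compound 2 by a larger change: hydroxy in place of ((furan-2-yl)methyl)amino on a carbonyl carbon. Two measured steps offer limited guidance. Furan-2-yl in place of 4-methoxyphenyl gave a 1.4-fold higher number from compound 1 to compound 2 (0.14 log units; within the scatter), and methyl in place of hydrogen on a saturated chain carbon gave a 1.4-fold lower number from compound 2 to compound 3 (0.14 log units; within the scatter). Neither step removes the whole ((furan-2-yl)methyl)amino group, so neither measures this change directly. Both stayed within the scatter, but the present change is larger, so a modest move towards a higher number is tentatively expected in this assay. The estimated step is a 1.6-fold higher number from compound 2 to compound 4 (0.20 log units; within the scatter). For compound 4, the estimated value is 90000 nM, with an expected range of 35000 nM to 250000 nM.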

Compound 4, half-maximal inhibitory concentration: > 100000 nM
Compound 4 gave a limit, no number; the forecaster's own chance of this, stated with the estimate: 30%; at least 1.1-fold (0.04 log units) between middle value and limit.
By their numbers in this assay, from the lowest: compounds 1, 3 and 2 (each within the scatter of the next). At a limit, above all of these: compound 4.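

Hydroxy in place of (4-methoxybenzyl)amino on a carbonyl carbon gave an at least 2.4-fold higher number from compound 1 to compound 4 (0.38 log units; beyond the scatter), the only step shown here that lies beyond the scatter in this assay. Hydroxy in place of ((furan-2-yl)methyl)amino at the same place gave an at least 1.7-fold higher number from compound 2 to compound 4 (0.24 log units; that floor lies within the scatter), so this floor alone does not separate compound 4 from compound 2. Compound 4 therefore shows that a change at this carbonyl carbon can move the number more than the earlier changes did, although its reading is a limit and not a number: the limit of > 100000 nM in this assay, at which 1 of the 4 values shown sits.

The compounds shown leave open how a primary amide or a methyl ester would read at this carbonyl carbon. They also leave open whether the higher number goes with losing the aromatic ring or with gaining the carboxy group, as both changes occur together in compound 4.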